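The source may report more compounds than this note shows. Statements on the series, on what has been measured and on what is new or still open speak of the compounds shown alone.

Measured in a functional assay on thoracic aorta (strain Wistar) for inhibition, with Aorta (Rattus norvegicus) as the target, in the presence of a further agent that is not named here; a higher number here means that more compound is needed for the effect, a lower number that less compound is needed:
- Compound 1 `O=C1OC(C(O)CO)C(OCCCOc2no[n+]([O-])c2S(=O)(=O)c2ccccc2)=C1O`: 7000 nM
- Compound 2 `O=C1OC(C(O)CO)C(OCCCCCCO[N+](=O)[O-])=C1O`: > 100000 nM, a limit
- Compound 3 `O=C1OC(C(O)CO)C(OCCCCC(CO[N+](=O)[O-])O[N+](=O)[O-])=C1O`: > 100000 nM, a limit

Going by the values given here, compound 1 holds the only actual number in this assay, since the other two values are limits. Compound 4 `O=C1OC(C(O)CO)C(OCCCOc2no[n+]([O-])c2-c2ccccc2)=C1O` differs from compound 1 in one place, with phenyl in place of phenylsulfonyl on an aromatic carbon. Among the compounds with values here, the single measured step, a step that the two limits leave unreadable from compound 2 to compound 3, concerns a saturated chain carbon and has no readable size, so it cannot size this change. Compound 1 alone carries phenylsulfonyl and gives 7000 nM. The other two compounds lack that group and rest on a limit: the limit of > 100000 nM in this assay, at which 2 of the 3 values shown sit. They also lack the rest of the side chain that compound 4 keeps, so this is a weak guide. A shift beyond the scatter towards a higher number in this assay is therefore expected, and the estimated step is a 5.0-fold higher number from compound 1 to compound 4 (0.70 log units; beyond the scatter). For compound 4 the expected value is 35000 nM, with an estimated range of 10000 nM to 100000 nM.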

Compound 4, half-maximal effective concentration: 80900 nM
Estimate against measurement, compound 4: 2.3-fold (0.36 log units) below; the measured number falls inside the stated range.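

Exchanging phenylsulfonyl for phenyl on this aromatic carbon gives a 12-fold higher number from compound 1 to compound 4 (1.06 log units; beyond the scatter) in this assay, the first readable size for any change among these compounds. Compound 1 and compound 4 differ in this one place only, so the large shift belongs to this change, with phenylsulfonyl going with the lower number. Compound 4 still gives a real number, not a limit, so the pair can be sized in a set where limits are otherwise common: the limit of > 100000 nM in this assay, at which 2 of the 4 values shown sit.

The step from compound 2 to compound 3 cannot be read, as both of its values are limits. Going by these compounds, whether a different group on this aromatic carbon, such as methylsulfonyl or a nitrile, or a longer chain in the linker of compound 1 would move the number remains open.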